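This account rests on a few compounds, and the source may have more. Where it says the series, first, only, none or still open, it means among the compounds named here.

Measured so far:
- compound 1, `COc1cc2ncnc(Nc3ccc(NC(=O)c4ccccc4C)cc3)c2cc1OC`: 21000 nM
- compound 2, `CCc1ccc(C(=O)Nc2ccc(Nc3ncnc4cc(OC)c(OC)cc34)cc2)cc1`: 65000 nM
- compound 3, `COc1cc2ncnc(Nc3ccc(NC(=O)c4ccccc4F)cc3)c2cc1OC`: 11000 nM

All three share one core and differ only in the aryl group on the carbonyl carbon of the amide. In a functional assay on MCF7 cells (Homo sapiens) for inhibition, read by MTT assay (on this read-out higher numbers stand for weaker inhibition and lower numbers for stronger inhibition), compound 3 gives the lowest of the three numbers, but the step of a 1.9-fold lower number from compound 1 to compound 3 (0.28 log units; within the scatter) is too small for these two compounds to be ordered; only compound 2 sits clearly apart, with a 5.9-fold lower number from compound 2 to compound 3 (0.77 log units; beyond the scatter).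

Compound 4, `COc1cc2ncnc(Nc3ccc(NC(=O)c4ccc(I)cc4)cc3)c2cc1OC`, is not yet measured. It differs from compound 3 as follows: 4-iodophenyl in place of 2-fluorophenyl on a carbonyl carbon.

Going by the values given here, two measured steps bear on this. Replacing 2-methylphenyl with 4-ethylphenyl gave a 3.1-fold higher number from compound 1 to compound 2 (0.49 log units; beyond the scatter), and going from 4-ethylphenyl to 2-fluorophenyl gave a 5.9-fold lower number from compound 2 to compound 3 (0.77 log units; beyond the scatter). Both moves from a 2-substituted to a 4-substituted phenyl went with a higher number in this assay. Iodine has no precedent here, so the weight of the change is uncertain, but the direction suggested by compounds 1, 2 and 3 is towards a higher number.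

Compound 4 is therefore expected to show a 3.2-fold higher number from compound 3 to compound 4 (0.50 log units; beyond the scatter), with an estimated value of 35000 nM and a range of 12000 nM to 90000 nM.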

Compound 4, half-maximal inhibitory concentration: 48000 nM
For compound 4 the middle estimate is 1.4-fold (0.14 log units) below the measured one; low and high end bracket the measured number.
By their numbers in this assay, from the lowest: compounds 3 and 1 (each within the scatter of the next); then compounds 4 and 2 (each within the scatter of the next).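

In this assay, the 4-iodophenyl amide separates from both amides carrying a 2-substituted phenyl, with a 4.4-fold higher number from compound 3 to compound 4 (0.64 log units; beyond the scatter) and a 2.3-fold higher number from compound 1 to compound 4 (0.36 log units; beyond the scatter), so the split seen so far with a single 4-ethylphenyl example now holds for a second group. Iodo in place of ethyl does not move the number beyond the usual scatter, with a 1.4-fold lower number from compound 2 to compound 4 (0.13 log units; within the scatter), so these two compounds cannot be ordered and the two groups, despite their different atoms, fall on the same side of the series. Among these four compounds, 2-methylphenyl and 2-fluorophenyl therefore sit on the low side and 4-ethylphenyl and 4-iodophenyl on the high side, with no compound against this split, but no available measurement offers an explanation for it.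

The compounds shown contain no single substituent at both places, such as 2-iodophenyl paired with 4-iodophenyl, so the location of the substituent and its identity remain confounded. Also open, going by these compounds, is where a phenyl carrying an amine or a carboxylic acid would fall relative to these two sets.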